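From a Chloro to a Fluoro Substituent in a Cytotoxicity Series

This account rests on a few compounds, and the source may have more. Where it says the series, first, only, none or still open, it means among the compounds named here.

Two compounds sharing one core have been assessed in a functional assay on MKN-45 cells (Homo sapiens) for cytotoxicity, read by MTT assay, with a stated time of 72 h; on this read-out higher numbers stand for weaker inhibition and lower numbers for stronger inhibition. Compound 1 `CN(C)CCn1cnnc1-c1cc(Oc2ccc(NC(=O)N/N=C/c3ccc(Cl)cc3)cc2F)ccn1` gives 570 nM in this assay, and compound 2 `CN(C)CCn1cnnc1-c1cc(Oc2ccc(NC(=O)N/N=C/c3ccc(O)c(O)c3)cc2F)ccn1` gives 3240 nM. Among these two numbers compound 1 holds the lowest; the only step available is a 5.7-fold higher number from compound 1 to compound 2 (0.75 log units; beyond the scatter), which arises from 3,4-dihydroxyphenyl in place of 4-chlorophenyl on a carbon with a double bond to nitrogen.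

Compound 3 `CN(C)CCn1cnnc1-c1cc(Oc2ccc(NC(=O)N/N=C/c3ccc(F)cc3)cc2F)ccn1` has not yet been measured. It differs from compound 1 in one place: fluoro in place of chloro on an aromatic carbon. Read one bond further out, the change is 4-chlorophenyl to 4-fluorophenyl. Within the data shown here, no measured step covers this exchange directly; the single step from compound 1 to compound 2 concerns a different replacement on the same carbon and only shows that alterations at that ring can move the read-out beyond the scatter. On that basis a modest shift is expected, most likely toward a somewhat higher number, although a result within the scatter of compound 1 would not surprise. The expected step is a 1.6-fold higher number from compound 1 to compound 3 (0.20 log units; within the scatter). Compound 3 is accordingly estimated at 900 nM, with a range from 400 nM to 2500 nM.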

Compound 3, half-maximal inhibitory concentration: 1030 nM
Estimate against measurement, compound 3: 1.1-fold (0.06 log units) below; the range from low to high includes it.
By their numbers in this assay, from the lowest: compounds 1 and 3 (each within the scatter of the next); then compound 2.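

In this assay, the exchange of chloro for fluoro on this aromatic carbon (a 1.8-fold higher number from compound 1 to compound 3 (0.26 log units; within the scatter)) stays within the usual scatter, so at this position one halogen can take the place of the other without a clear change in the read-out, which the earlier replacement of 4-chlorophenyl by 3,4-dihydroxyphenyl could not show. The 4-fluorophenyl compound also stands clearly apart from the 3,4-dihydroxyphenyl compound (a 3.1-fold lower number from compound 2 to compound 3 (0.50 log units; beyond the scatter)), so among these three compounds the two that carry a single halogen on this ring both give lower numbers than compound 2, which is the only one with two hydroxyl groups there. No measured information is at hand that would explain either the match between the two halogens or their separation from compound 2.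

The compounds shown leave open how a bromo, a methoxy or an amino group on the same aromatic carbon would read, and whether an unsubstituted phenyl would fall with the two halogen compounds or closer to compound 2. They also leave open whether a single hydroxyl group, rather than two, would be enough to give a number as high as that of compound 2.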